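Same atoms, joined differently, on compound 2

The source may hold more compounds than are shown below. What is called first, only, known or untested is meant among the compounds shown, and "the series" means these compounds.

Among the measured compounds shown here, in a physicochemical assay for solubility, measured as kinetic solubility (on this read-out higher numbers stand for higher solubility and lower numbers for lower solubility), compound 2 `Cc1cc(C)c(CN2CCc3c(Cl)cc([C@H](CO)[C@@H]4CCCO4)c(Cl)c3C2=O)c(=O)[nH]1` gives 400000 nM, its only number, and one further entry holds no single number. Compound 3 `Cc1cc(C)c(CN2CCc3c(Cl)cc([C@@H](CO)[C@@H]4CCOC4)c(Cl)c3C2=O)c(=O)[nH]1` has the same atoms joined differently in the group on an aromatic carbon of the shared core: a group of 8 heavy atoms (6 carbon, 2 oxygen; one five-membered non-aromatic ring with 1 hetero atom) in place of a group of 8 heavy atoms (6 carbon, 2 oxygen; one five-membered non-aromatic ring with 1 hetero atom), on an aromatic carbon. For the measured compounds named here, no measured step guides this change. Compound 1 `COC(c1cc(Cl)c2c(c1Cl)C(=O)N(Cc1c(C)cc(C)[nH]c1=O)CC2)C1CCOC1` gives 415000 nM; 457000 nM; 439000 nM; 436000 nM (4 entries), close to compound 2 at 400000 nM, so no step beyond the usual scatter is expected. The expected change is no change at the digits printed from compound 2 to compound 3 (within the scatter). Compound 3 is expected at about 400000 nM, with an estimated range of 220000 nM to 600000 nM.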

Compound 3, solubility: 537000 nM
For compound 3 the middle estimate is 1.3-fold (0.13 log units) below the measured one, within the range that was stated.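

Among the compounds shown here, this is the first step that can be read at this position. For the compounds shown here, with the atoms of the group on the aromatic carbon joined differently and its five-membered non-aromatic ring kept, this assay shows a 1.3-fold higher number from compound 2 to compound 3 (0.13 log units; within the scatter), so this rearrangement gives no step that stands out from the scatter. Repeat entries of a single compound show how far such numbers spread on their own: the several entries of compound 1 in this assay, 415000 nM; 457000 nM; 439000 nM; 436000 nM (4 entries)

From the compounds shown here alone, whether a group of another kind on this aromatic carbon, such as an amine or a carboxylic acid, would shift the number remains open. Going by these compounds, the effect of the two defined stereocentres taken alone also remains open, as compound 2 and compound 3 differ in how the atoms are joined as well.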